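The compounds below may be only part of what the source reports. "The series", "measured", "known", "first", "only" and "open" are said of these compounds alone.

In a functional assay on MCF7 cells (Homo sapiens) for inhibition, read by MTT assay (on this read-out lower numbers stand for stronger inhibition and higher numbers for weaker inhibition), compound 1 (`COc1cc2ncnc(Nc3ccc(NC(=O)c4ccc(I)cc4)cc3)c2cc1OC`) reads 48000 nM as the reference value. Compound 2 (`COc1cc2ncnc(Nc3ccc(NC(=O)c4c(F)cccc4F)cc3)c2cc1OC`) reads 24000 nM and so stands within the scatter of compound 1. Compound 3 (`COc1cc2ncnc(Nc3ccc(NC(=O)c4ccc(Cl)c(Cl)c4)cc3)c2cc1OC`) has 3,4-dichlorophenyl in place of 2,6-difluorophenyl on a carbonyl carbon. For the measured compounds named here, the one measured step at that carbonyl carbon is a 2.0-fold lower number from compound 1 to compound 2 (0.30 log units; within the scatter) and it stays within the scatter. On this single pair, no step beyond the scatter is expected in this assay here. The expected step is a 1.3-fold higher number from compound 2 to compound 3 (0.10 log units; within the scatter) and no direction is favoured. Compound 3 is estimated at 30000 nM with an expected range from 12000 nM to 70000 nM for this read-out.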

Compound 3, half-maximal inhibitory concentration: 25000 nM
Compound 3: the middle estimate sits 1.2-fold (0.08 log units) above what was measured; low and high end bracket the measured number.
By their numbers in this assay, from the lowest: compounds 2, 3 and 1 (each within the scatter of the next).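

Working notes: the steps of a 1.0-fold higher number from compound 2 to compound 3 (0.02 log units; within the scatter) and a 1.9-fold lower number from compound 1 to compound 3 (0.28 log units; within the scatter) both stay within the scatter in this assay on this carbonyl carbon. With 3,4-dichlorophenyl added, three differently halogenated phenyl groups at this position now show no step beyond the scatter, including a change of both halogen and its placement at equal heavy-atom count. No measured evidence accounts for this flat result. Still open, going by these compounds, is whether any group on this carbonyl carbon moves the read-out beyond the scatter. A phenyl carrying an amine or a carboxylic acid, or a non-aromatic longer chain, would test that.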